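Tetrabrominated core series: aryl group replaced by methyl

This account rests on a few compounds, and the source may have more. Where it says the series, first, only, none or still open, it means among the compounds named here.

Measured so far in a functional assay on CCRF-CEM cells (Homo sapiens) for antiproliferative activity, read by MTT assay, with a stated time of 24 h, tested at 50 uM; a lower number here means a stronger effect, a higher number a weaker effect of the compound at the concentration tested:
compound 1 `OC(CCn1nc2c(Br)c(Br)c(Br)c(Br)c2n1)c1cccc(Br)c1` gives 54%
compound 2 `OC(CCn1nc2c(Br)c(Br)c(Br)c(Br)c2n1)c1ccc(Br)cc1` gives 58%

Going by the values given here, compound 2 stands at the upper of the two numbers in this assay, but the only measured step, a number 4 percentage points higher from compound 1 to compound 2 (within the scatter), is within the scatter, so the two compounds are not told apart. Compound 3 `CC(O)CCn1nc2c(Br)c(Br)c(Br)c(Br)c2n1` is not yet measured; from compound 2 it differs by methyl in place of 4-bromophenyl on a saturated chain carbon bound to an oxygen on a saturated carbon and a saturated chain carbon. Among the compounds with values here, no measured step bears on this change: the single known step exchanges one bromophenyl for another, whereas here the ring leaves entirely. Compound 3 is expected to give 68%, range 45% to 92%, a step of a number 10 percentage points higher from compound 2 to compound 3 (within the scatter) estimated without a measured parallel.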

Compound 3, a percentage reported as activity, at one concentration (the size of the read-out at that concentration, not a potency): 89%
For compound 3 the middle estimate is 21 percentage points below the measured one, within the range that was stated.
By their numbers in this assay, from the lowest: compounds 1 and 2 (each within the scatter of the next); then compound 3.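

In this assay the aryl group at this position counts for the effect: methyl in place of 4-bromophenyl gives a number 31 percentage points higher from compound 2 to compound 3 (beyond the scatter) and methyl in place of 3-bromophenyl gives a number 35 percentage points higher from compound 1 to compound 3 (beyond the scatter) with both steps towards a weaker effect. Exchanging one bromophenyl for the other did not separate compounds, whereas removing the ring does. Nothing at hand explains this loss of effect.

Open, from the compounds shown here alone, is whether an unsubstituted phenyl would hold the effect of the bromophenyl compounds, which would separate the part of the ring from that of its bromine. Open too, going by these compounds, is whether a non-aromatic ring such as cyclohexyl could stand in for the aryl group.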